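Swapping the thiophene for a methyl-oxadiazole on the imidazoline scaffold

This account rests on a few compounds, and the source may have more. Where it says the series, first, only, none or still open, it means among the compounds named here.

Compound 2 `Cc1ccsc1-c1ccccc1NCC1=NCCN1` carries a 3-methylthiophen-2-yl group on the shared core, and in a functional assay for activation of Alpha-1B adrenergic receptor (Homo sapiens), read by calcium flux (on this read-out higher numbers stand for an effect only at larger amounts of compound and lower numbers for an effect already at smaller amounts), compound 2 gives 112 nM. Going by the values given here, this is the highest of the two numbers measured so far; its nearest neighbour is compound 1 `c1csc(-c2ccccc2NCC2=NCCN2)c1`, which in this assay gives 5.75 nM. Among the compounds with values here, the only measured step, a 19-fold higher number from compound 1 to compound 2 (1.29 log units; beyond the scatter), came from a methyl in place of hydrogen on an aromatic carbon. Compound 3 `Cc1nc(-c2ccccc2NCC2=NCCN2)no1` differs from compound 2 by 5-methyl-1,2,4-oxadiazol-3-yl in place of 3-methylthiophen-2-yl on an aromatic carbon. Within the data shown here, no measured step touches an exchange of the whole five-membered ring; the one step known concerns only the methyl, which compound 3 retains on its new ring. The expectation for this assay is therefore held loosely: a step of a 2.2-fold higher number from compound 2 to compound 3 (0.35 log units; beyond the scatter) from compound 2 to compound 3 is estimated, with the direction taken as a mild further rise but not firmly beyond the scatter. For compound 3 the estimate in this assay is 250 nM, within a range of 40 nM to 2500 nM.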

Compound 3, half-maximal effective concentration: 676 nM
The estimate for compound 3 lay 2.7-fold (0.43 log units) below the measured number; the range from low to high includes it.
By their numbers in this assay, from the lowest: compound 1; then compound 2; then compound 3.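

With the methyl kept and the count of 6 heavy atoms unchanged, exchanging the ring itself still moved the number in this assay further up (a 6.0-fold higher number from compound 2 to compound 3 (0.78 log units; beyond the scatter)), so this position responds to the ring that carries the methyl and not to the methyl alone. Set against the thiophen-2-yl group of the core of compound 1, the 5-methyl-1,2,4-oxadiazol-3-yl group gives the largest step seen so far (a 120-fold higher number from compound 1 to compound 3 (2.07 log units; beyond the scatter)), and it leaves compound 3 with the highest number of the three, beyond the scatter from both others. Neither change tried at this aromatic carbon has gone below compound 1, which so far holds the lowest number.

No measurement at hand bears on why the exchange of the ring acts in this way. Still open, from the compounds shown here alone, is how a 1,2,4-oxadiazole ring would read without its methyl, which would separate the two changes, and whether a phenyl ring or a methoxy group on the same aromatic carbon would stay near compound 1 or near compound 3.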